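Halogen swap on thioamide versus amide in a cytotoxicity assay

The compounds below may be only part of what the source reports. "The series", "measured", "known", "first", "only" and "open" are said of these compounds alone.

Notes on the series; all numbers come from a functional assay on HepG2 cells (Homo sapiens) for cytotoxicity, with a stated time of 24 h; a higher number here means a weaker inhibitor, a lower number a stronger inhibitor.

compound 1 : `COc1cc(Cl)ccc1C(=O)Nc1ccc(Cl)cc1O`, 7340 nM
compound 2 : `COc1cc(Cl)ccc1C(=O)Nc1ccc(Br)cc1O`, 46600 nM
compound 3 : `COc1cc(Cl)ccc1C(=S)Nc1ccc(Cl)cc1O`, 5110 nM

Within the measured set, compound 1 and compound 2 share the amide core and differ in one place: bromo in place of chloro on an aromatic carbon. That change gave a 6.3-fold higher number from compound 1 to compound 2 (0.80 log units; beyond the scatter) in this assay. Compound 3 carries the thioamide core; how its core differs from that of compound 1 is not broken down here. In this assay compound 3 gives 5110 nM, and compound 1 gives 7340 nM; these two numbers lie within the scatter of each other, so no order between compound 1 and compound 3 is claimed. Against compound 2 the number for compound 3 is beyond the scatter.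

Compound 4, `COc1cc(Cl)ccc1C(=S)Nc1ccc(Br)cc1O`, is not yet measured in this assay. It relates to compound 3 as compound 2 relates to compound 1, through the same change: bromo in place of chloro on an aromatic carbon. Among the measured compounds shown here, with only the one measured instance of this change, from compound 1 to compound 2, the expectation for compound 4 rests on that step alone. The step from compound 3 to compound 4 is expected to be a 5.5-fold higher number from compound 3 to compound 4 (0.74 log units; beyond the scatter), because the same change gave a 6.3-fold higher number from compound 1 to compound 2 (0.80 log units; beyond the scatter). Compound 4 is accordingly estimated at 28000 nM in this assay, with a range from 9000 nM to 85000 nM, the width reflecting that a single prior step carries the whole expectation.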

Compound 4, half-maximal inhibitory concentration: 3880 nM
The estimate for compound 4 lay 7.2-fold (0.86 log units) above the measured number, outside the stated range (below it).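

On the thioamide core, bromo in place of chloro gave a 1.3-fold lower number from compound 3 to compound 4 (0.12 log units; within the scatter) in this assay, so no order between these two compounds is claimed. Set beside the amide pair, this shows that the step measured on one core did not carry over to the other in this assay, and that the size of this halogen swap in the series depends on the core that bears it: the same change on two cores in this assay, a 6.3-fold higher number (0.80 log units; beyond the scatter) from compound 1 to compound 2 and a 1.3-fold lower number (0.12 log units; within the scatter) from compound 3 to compound 4, 8.4-fold (0.92 log units) apart, beyond the scatter of two such steps It does not show which feature of the two cores lies behind the gap, nor how general the gap is, since each core contributes a single pair of compounds, and a single pair cannot say which of the two steps is more typical of the change on other cores in the series.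

The compounds shown leave open whether fluoro, iodo or a nitrile at the same place would also separate the amide and thioamide cores, or whether the gap is confined to the swap of chloro for bromo. They also leave open whether the gap persists when the hydroxy group gives way to an amine or a carboxylic acid, or the methoxy group to a longer chain.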